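This account rests on a few compounds, and the source may have more. Where it says the series, first, only, none or still open, it means among the compounds named here.

Compound 1 `O=C(CNC(=O)c1cc(Cl)ccc1O)Nc1cccc(Cl)c1` carries a glycine-type linker between a substituted benzamide and a chloroanilide. In a functional assay on MCF7 cells (Homo sapiens) for cytotoxicity, with a stated time of 72 h (a higher number here means a weaker inhibitor, a lower number a stronger inhibitor), compound 1 gives > 10000 nM, which is a limit of the assay rather than a number. Compound 2 `C[C@H](NC(=O)c1cc(Cl)ccc1O)C(=O)Nc1cccc(Cl)c1` gives > 10000 nM, also a limit. Compound 3 `CC(C)[C@@H](NC(=O)c1cc(Cl)ccc1O)C(=O)Nc1cccc(Cl)c1` gives > 10000 nM, again a limit. The change from compound 1 to compound 2 is a step that the two limits leave unreadable from compound 1 to compound 2, and that from compound 1 to compound 3 is a step that the two limits leave unreadable from compound 1 to compound 3; both remain unreadable because of the limit of > 10000 nM in this assay, at which 3 of the 3 values shown sit. Compound 4 `O=C(CNC(=O)c1cc(Cl)ccc1O)Nc1ccc(Cl)c(Cl)c1` differs from compound 1 by chloro in place of hydrogen on an aromatic carbon. Among the measured compounds shown here, none of the measured steps touches this aromatic ring; they all alter the chain carbon, so nothing measured bears directly on the new change, and every measured compound sits at the same limit. The expected step from compound 1 to compound 4 is therefore a step that the limit leaves unreadable from compound 1 to compound 4, with the new value most likely reported as a limit as well. Compound 4 is estimated at 12000 nM, within a range from 4000 nM to 40000 nM.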

Compound 4, half-maximal inhibitory concentration: > 20000 nM
Compound 4 ended at the assay's limit; the forecaster's own chance of this, stated with the estimate: 70%; at least 1.6-fold (0.22 log units) between middle value and limit.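

In this assay compound 4 gives > 20000 nM, which is a limit and not a number. Compound 1 also stands at a limit, so no step can be read between compound 1 and compound 4. The compounds shown leave open whether the added chloro changes potency at all.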